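The source may report more compounds than this note shows. Statements on the series, on what has been measured and on what is new or still open speak of the compounds shown alone.

Measured compounds:
compound 1, `OC12CCCC3CC(CCC31)C2`: 6000000 nM
compound 2, `O=C(O)C12CCCC3CC(CCC31)C2`: 10000000 nM
compound 3, `OCC12CCCC3CC(CCC31)C2`: 870000 nM

In an ADME assay (Gallus gallus) for cytotoxicity, read by microscopy, with a stated time of 24 h (a lower number here means that less compound is tolerated, a higher number that more compound is tolerated), compound 2 gives 10000000 nM, the highest of the three numbers. Its nearest neighbour is compound 1, and the step of a 1.7-fold higher number from compound 1 to compound 2 (0.22 log units; within the scatter) is small, so the two cannot be told apart. Compound 3 lies much further away: the step of an 11-fold lower number from compound 2 to compound 3 (1.06 log units; beyond the scatter) is a large drop, and compound 1 shows a similar move in a 6.9-fold lower number from compound 1 to compound 3 (0.84 log units; beyond the scatter).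

Compound 4, `CCCCNC(=O)C12CCCC3CC(CCC31)C2`, differs from compound 2 in one place: butylamino in place of hydroxy on a carbonyl carbon. Among the measured compounds shown here, none of the measured steps swaps the hydroxy of a carboxy group for an amine, so there is no direct precedent. For the measured compounds named here, the only measured change that removed the carboxy group, an 11-fold lower number from compound 2 to compound 3 (1.06 log units; beyond the scatter), lowered the number a lot, and the sole pair that stayed within the scatter, a 1.7-fold higher number from compound 1 to compound 2 (0.22 log units; within the scatter), kept both groups small. A larger group replacing the carboxy is therefore expected to move the number down, as a modest step of a 6.7-fold lower number from compound 2 to compound 4 (0.82 log units; beyond the scatter), though with wide uncertainty. For compound 4 the estimate in this assay is 1500000 nM, with a likely range from 300000 nM to 6000000 nM.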

Compound 4, minimum cytotoxic concentration: 300000 nM
Estimate against measurement, compound 4: 5.0-fold (0.70 log units) above; the range from low to high includes it.
By their numbers in this assay, from the lowest: compound 4; then compound 3; then compounds 1 and 2 (each within the scatter of the next).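

Swapping only the hydroxy on the carbonyl carbon for butylamino, with the carbonyl itself kept, has a large effect in this assay: the step is a 33-fold lower number from compound 2 to compound 4 (1.52 log units; beyond the scatter). The earlier steps shown here all exchanged a whole group on a saturated ring carbon, so this result adds something new: at this position a change further out on the group, at the carbonyl carbon alone, can also lower the number well beyond the scatter, meaning that less compound is tolerated. Nothing measured here accounts for this drop, so the result describes the size of the change and gives no explanation for it.

As far as these compounds go, what remains open is whether the drop goes with the amide link itself or with the butyl chain it carries, since a single amide cannot show a trend with chain length. A plain amino group or a methylamino group on the same carbonyl carbon, a longer chain such as octylamino, and a methyl ester with oxygen in place of the nitrogen would help separate these two possibilities.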